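Swapping the aryl group on the saturated ring carbon

The source may report more compounds than this note shows. Statements on the series, on what has been measured and on what is new or still open speak of the compounds shown alone.

Compound 1, `CCC(=O)N1C[C@@H](C(=O)N2CCN(c3ccc(C)cc3[C@@H](NC(=O)CCN(C)C)C(C)C)CC2)[C@H](c2ccc(Cl)cc2)C1`, in an assay on HEK293 cells for displacement of a labelled ligand from Melanocortin receptor 4 (Homo sapiens) (a higher number here means a weaker inhibitor, a lower number a stronger inhibitor), gives 4.6 nM.
Compound 2, `CC(C)[C@H](NC(=O)CCN(C)C)c1cccc(F)c1N1CCN(C(=O)[C@@H]2CN(C(C)C)C[C@H]2c2ccc(F)c(Cl)c2)CC1`, gives 260 nM.
Compound 3, `CC(C)[C@H](NC(=O)CCN(C)C)c1cccc(F)c1N1CCN(C(=O)[C@@H]2CN(C(C)C)C[C@H]2c2cc(F)ccc2F)CC1`, gives 2050 nM.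

Compound 3 has the highest number of the three; compound 2 stands nearest to it and compound 1 furthest. Compound 4, `CC(C)[C@H](NC(=O)CCN(C)C)c1cccc(F)c1N1CCN(C(=O)[C@@H]2CN(C(C)C)C[C@H]2c2cccc(Cl)c2)CC1`, carries 3-chlorophenyl in place of 2,5-difluorophenyl on a saturated ring carbon. Among the measured compounds shown here, the one measured step that bears on this change, a 7.9-fold higher number from compound 2 to compound 3 (0.90 log units; beyond the scatter), shows that the aryl group on that carbon can shift the number considerably, and compound 2 itself carries 3-chloro-4-fluorophenyl at that position. A lower number for compound 4 is therefore expected, with a step of a 5.9-fold lower number from compound 3 to compound 4 (0.77 log units; beyond the scatter) that largely undoes that earlier rise. Compound 4 is estimated at 350 nM, with a range from 100 nM to 1200 nM.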

Compound 4, inhibition constant: 370 nM
The estimate for compound 4 lay 1.1-fold (0.02 log units) below the measured number, and the stated range covers the measured number.
By their numbers in this assay, from the lowest: compound 1; then compounds 2 and 4 (each within the scatter of the next); then compound 3.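

The step of a 5.5-fold lower number from compound 3 to compound 4 (0.74 log units; beyond the scatter) shows that a single chloro-bearing aryl group on this saturated ring carbon is enough to bring the number down from that of the 2,5-difluorophenyl compound. Hydrogen in place of the fluoro of compound 2 gives a 1.4-fold higher number from compound 2 to compound 4 (0.15 log units; within the scatter), so that fluoro makes no difference that can be read here. No measurement bears on why these aryl groups differ.

A plain phenyl or a 3-methylphenyl group on that carbon would show whether the chloro group itself matters. As far as these compounds go, compound 1, at 4.6 nM, differs from compound 4 in more than one place, so what separates them stays open.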